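Bromo in place of chloro on compound 2

A few compounds are considered here, and "the series" means these few. Any claim that something is new, unique, unknown or untested is made for them only; others in the source may bear on it.

compound 1 `COc1cc(OC)c(/C=C/S(=O)(=O)Nc2ccc(OC)c(N)c2)c(OC)c1`: 5 nM
compound 2 `COC(=O)C(Nc1cc(NS(=O)(=O)/C=C/c2c(OC)cc(OC)cc2OC)ccc1OC)c1ccc(Cl)cc1`: 5000 nM

In a functional assay on DU-145 cells (Homo sapiens) for cytotoxicity, read by trypan blue exclusion, with a stated time of 96 h (on this read-out lower numbers stand for stronger inhibition and higher numbers for weaker inhibition), compound 2 gives 5000 nM, the higher of the two numbers and so the weaker result. Compound 3 `COC(=O)C(Nc1cc(NS(=O)(=O)/C=C/c2c(OC)cc(OC)cc2OC)ccc1OC)c1ccc(Br)cc1` differs from it in one place: bromo in place of chloro on an aromatic carbon. The 4-chlorophenyl of compound 2 thus becomes 4-bromophenyl in compound 3, and the rest of the structure stays the same.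

Going by the values given here, the only measured step, a 1000-fold higher number from compound 1 to compound 2 (3.00 log units; beyond the scatter), is large, but it bears on this change only loosely. It puts a whole (4-chlorophenyl)(methoxycarbonyl)methyl in place of hydrogen on a nitrogen on an aromatic ring, whereas the new change alters only the halogen within that group. Among the compounds with values here, no measured pair shows bromo in place of chloro, so the data favour no direction. In this assay, no step beyond the scatter is therefore expected, and the best starting point is compound 2 at 5000 nM. The expected step is no change at the digits printed from compound 2 to compound 3 (within the scatter). The estimate for compound 3 is 5000 nM, with an expected range of 2000 nM to 12000 nM.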

Compound 3, half-maximal inhibitory concentration: 7500 nM
Compound 3: the middle estimate sits 1.5-fold (0.18 log units) below what was measured; the measured number falls inside the stated range.
By their numbers in this assay, from the lowest: compound 1; then compounds 2 and 3 (each within the scatter of the next).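

In this assay, going by these compounds alone, the first direct look at bromo in place of chloro on this aromatic carbon gives a 1.5-fold higher number from compound 2 to compound 3 (0.18 log units; within the scatter), so the two halogens cannot be told apart at this position. The large gap to the parent amine also holds with the new halogen, at a 1500-fold higher number from compound 1 to compound 3 (3.18 log units; beyond the scatter), which shows that the earlier jump was not peculiar to the (4-chlorophenyl)(methoxycarbonyl)methyl group: (4-bromophenyl)(methoxycarbonyl)methyl on that nitrogen goes with the same weak result. No supporting measurement is available to explain either step.

The compounds shown leave open which part of the added group goes with the large step, since the phenyl ring, its halogen and the methoxycarbonyl always enter together; a plain methyl on that nitrogen, or a carboxylic acid in place of the methoxycarbonyl, would help to separate them. Within the data shown here, they also leave open whether this ring carbon responds to anything other than a halogen, such as an amine, as chloro and bromo are the only two groups seen there.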